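A Fourth Aryl Group on the Shared Core

A few compounds are considered here, and "the series" means these few. Any claim that something is new, unique, unknown or untested is made for them only; others in the source may bear on it.

Three urea compounds built on a shared core have been tested in a functional assay on HepG2 cells (Homo sapiens) for inhibition, read by MTT assay, with a stated time of 72 h; a higher number here means a weaker inhibitor, a lower number a stronger inhibitor. Compound 1 `Cc1ccccc1-n1cc(COc2cccc(NC(=O)Nc3ccc(Cl)c(C(F)(F)F)c3)c2)nn1` gives 3440 nM in this assay. Compound 2 `CCc1ccccc1-n1cc(COc2cccc(NC(=O)Nc3ccc(Cl)c(C(F)(F)F)c3)c2)nn1` gives 3530 nM, and compound 3 `N#Cc1ccc(-n2cc(COc3cccc(NC(=O)Nc4ccc(Cl)c(C(F)(F)F)c4)c3)nn2)cc1` gives 2980 nM. Compound 1 stands second highest of the three numbers; its nearest neighbour is compound 2 and its furthest is compound 3, and both of those gaps fall within the scatter, so the three compounds cannot be told apart on these numbers.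

Compound 4 `CCc1ccc(-n2cc(COc3cccc(NC(=O)Nc4ccc(Cl)c(C(F)(F)F)c4)c3)nn2)cc1` has not yet been measured. It differs from compound 1 in one place: 4-ethylphenyl in place of 2-methylphenyl on an aromatic nitrogen. Within the data shown here, two measured steps bear on this change. The step of a 1.2-fold lower number from compound 1 to compound 3 (0.06 log units; within the scatter) shows that exchanging the 2-methylphenyl on the aromatic nitrogen for a 4-cyanophenyl left the number within the scatter, and the step of a 1.0-fold higher number from compound 1 to compound 2 (0.01 log units; within the scatter) shows that adding one carbon to a saturated chain also left it within the scatter. The step of a 1.2-fold lower number from compound 2 to compound 3 (0.07 log units; within the scatter) points the same way. No step beyond the scatter is therefore expected for compound 4, in either direction. Compound 4 is estimated at 3300 nM in this assay, with a range of 1700 nM to 6600 nM, which means an expected step of a 1.0-fold lower number from compound 1 to compound 4 (0.02 log units; within the scatter).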

Compound 4, half-maximal inhibitory concentration: 1950 nM
The estimate for compound 4 lay 1.7-fold (0.23 log units) above the measured number, and the stated range covers the measured number.
By their numbers in this assay, from the lowest: compounds 4, 3, 1 and 2 (each within the scatter of the next).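

In this assay, placing 4-ethylphenyl on the aromatic nitrogen gives a 1.8-fold lower number from compound 1 to compound 4 (0.25 log units; within the scatter) and a 1.8-fold lower number from compound 2 to compound 4 (0.26 log units; within the scatter); these steps are wider than any among compounds 1, 2 and 3, yet both remain within the scatter. Ethyl in place of cyano on the aromatic carbon gives a 1.5-fold lower number from compound 3 to compound 4 (0.18 log units; within the scatter), also within the scatter, so the four aryl groups shown on this nitrogen cannot be told apart and none yields a step beyond the scatter. Nothing measured here offers an explanation for these numbers.

Going by these compounds, it remains open whether a 4-aminophenyl, a 4-carboxyphenyl or a 4-butylphenyl on the same nitrogen would give a step beyond the scatter. The compounds shown also leave open how 4-ethylphenyl would read if the chlorine or the trifluoromethyl of the shared core were replaced.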